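This account rests on a few compounds, and the source may have more. Where it says the series, first, only, none or still open, it means among the compounds named here.

Measured so far:
- compound 1 `COc1ccc2c(c1)OC(c1ccccc1)CC2=O`: 1470 nM
- compound 2 `Cc1ccc([C@@H]2CC(=O)c3ccc(F)cc3O2)cc1`: 150 nM

In an in vitro assay on BTI-TN-5B1-4 cells for inhibition of Amine oxidase [flavin-containing] B (Homo sapiens) (a higher number here means a weaker inhibitor, a lower number a stronger inhibitor), compound 1 gives 1470 nM, the highest of the two numbers shown, while compound 2 gives 150 nM; the gap between the two lies beyond the scatter. Compound 2 differs from compound 1 in two places, so only the two values themselves can be compared. Compound 3 `COc1ccc2c(c1)OC(c1ccc(C)cc1)CC2=O` carries methyl in place of hydrogen on an aromatic carbon on the core of compound 1. Among the measured compounds shown here, no measured single step of this kind exists. The step from compound 1 to compound 3 is expected to lower the number moderately, a 2.9-fold lower number from compound 1 to compound 3 (0.47 log units; beyond the scatter), because compound 2 gives 150 nM and also carries that methyl. Compound 3 is estimated at 500 nM, within 150 nM to 1600 nM.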

Compound 3, half-maximal inhibitory concentration: 550 nM
Compound 3: middle estimate off by 1.1-fold (0.04 log units), on the low side; low and high end bracket the measured number.
By their numbers in this assay, from the lowest: compound 2; then compound 3; then compound 1.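

In this assay the change of methyl in place of hydrogen on an aromatic carbon, para to a large group, gives a 2.7-fold lower number from compound 1 to compound 3 (0.43 log units; beyond the scatter). Among the compounds shown here, this is the first step that isolates one change, and it shows that this single carbon alone moves the number on the core of compound 1. Nothing available accounts for the size of this step. Still open, from the compounds shown here alone, is whether a longer chain such as ethyl, or a chlorine atom, at this place would lower the number further. An amine or a carboxylic acid there also remains untested in the compounds shown.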